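Chloro for fluoro: from compound 1 to compound 4

A few compounds are considered here, and "the series" means these few. Any claim that something is new, unique, unknown or untested is made for them only; others in the source may bear on it.

Values so far in a functional assay on LOX IMVI cells (Homo sapiens) for cytotoxicity, read by MTT assay, with a stated time of 24 h (a lower number here means a stronger inhibitor, a higher number a weaker inhibitor), for the measured compounds:
- compound 1 `O=S(=O)(NCCCNc1nccc(-c2[nH]c(-c3ccccc3)nc2-c2ccc(F)c(O)c2)n1)c1ccc(C(F)(F)F)cc1` gives 2450 nM
- compound 2 `O=S(=O)(NCCCNc1nccc(-c2[nH]c(-c3ccccc3)nc2-c2ccc(F)c(O)c2)n1)c1cccc(F)c1` gives 7890 nM
- compound 3 `O=S(=O)(NCCCNc1nccc(-c2[nH]c(-c3ccccc3)nc2-c2ccc(F)c(O)c2)n1)c1cccc2ccccc12` gives 3710 nM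

Compound 1 sits at the low end of this short range together with compound 3, the two being indistinguishable (a 1.5-fold higher number from compound 1 to compound 3 (0.18 log units; within the scatter)), while compound 2 lies clear of it (a 3.2-fold higher number from compound 1 to compound 2 (0.51 log units; beyond the scatter)).

Compound 4 `O=S(=O)(NCCCNc1nccc(-c2[nH]c(-c3ccccc3)nc2-c2ccc(Cl)c(O)c2)n1)c1ccc(C(F)(F)F)cc1` has not been measured. Its change from compound 1 is chloro in place of fluoro on an aromatic carbon (chloro in place of fluoro on an aromatic carbon, ortho to a hydroxy group and para to a large group), which turns 4-fluoro-3-hydroxyphenyl into 4-chloro-3-hydroxyphenyl.

All three measured steps replace the group on the sulfonyl sulfur, so none of them tests this position. They serve only as a rough gauge of movement in the series, the remaining one being modest (a 2.1-fold lower number from compound 2 to compound 3 (0.33 log units; beyond the scatter)). The data hold no halogen exchange at this site, so neither size nor direction can be read from them. Compound 1 (2450 nM) is therefore the only anchor, and in this assay no step beyond the scatter is expected, in either direction. The expected step is small (a 1.1-fold higher number from compound 1 to compound 4 (0.03 log units; within the scatter)). Compound 4 is expected at 2600 nM within an estimated range from 1200 nM to 5500 nM in this series.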

Compound 4, half-maximal inhibitory concentration: 10100 nM
Compound 4: the middle estimate sits 3.9-fold (0.59 log units) below what was measured; measured number outside the range, above it.
By their numbers in this assay, from the lowest: compounds 1 and 3 (each within the scatter of the next); then compounds 2 and 4 (each within the scatter of the next).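

In this assay, the halogen on the 4-fluoro-3-hydroxyphenyl group proves not to be a silent site: the single-atom exchange of chloro in place of fluoro gives a 4.1-fold higher number from compound 1 to compound 4 (0.62 log units; beyond the scatter) and so moves the number beyond the scatter. For the compounds shown here, every earlier step changed the group on the sulfonyl sulfur, so this is the first sign that the series also responds at this aromatic carbon, ortho to the hydroxy group, with a step of the same modest class as a 3.2-fold higher number from compound 1 to compound 2 (0.51 log units; beyond the scatter) on the sulfonyl side. No measurement at hand bears on what lies behind this step.

The compounds shown leave open how hydrogen, bromo, methyl or methoxy would read at this carbon, so a single exchange marks one point and not a trend across substituents. They also leave open whether chloro in place of fluoro carries a similar step when 3-fluorophenyl or naphthalen-1-yl stands on the sulfonyl sulfur instead of 4-(trifluoromethyl)phenyl.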